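Moving a Methoxy Group on a Remote Phenoxy Ring

This account rests on a few compounds, and the source may have more. Where it says the series, first, only, none or still open, it means among the compounds named here.

Of the compounds shown here, three built on one shared core have been measured in a physicochemical assay for acid dissociation. Compound 1 `COc1ccc(-c2ccc3c(NCCCNCc4cccc(OC)c4O)ccnc3c2)cc1` gives 9.47. Compound 2 `COc1cccc(CNCCCNc2ccnc3cc(C4CCCCC4)ccc23)c1O` gives 9.47. Compound 3 `COc1ccc(Oc2ccc3c(NCCCNCc4cccc(OC)c4O)ccnc3c2)cc1` gives 9.28, which is the lowest of the three numbers, although its nearest neighbour is compound 1 and its furthest is compound 2, and both gaps lie within the scatter, so no order among the three can be claimed.

The steps between them read as follows: no change at the digits printed from compound 1 to compound 2 (within the scatter), a number 0.19 log units lower from compound 1 to compound 3 (within the scatter) and a number 0.19 log units lower from compound 2 to compound 3 (within the scatter). None of them reaches beyond the scatter, so exchanging the group on the aromatic carbon of the core has left the measured proton untouched in every case so far.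

Compound 4 `COc1ccccc1Oc1ccc2c(NCCCNCc3cccc(OC)c3O)ccnc2c1` differs from compound 3 only in 2-methoxyphenyl in place of 4-methoxyphenyl on an oxygen on an aromatic ring. This alteration sits within the very group whose exchange gave the small steps from compound 1 and from compound 2 to compound 3, and those steps were within the scatter. The account therefore expects a number 0.02 log units higher from compound 3 to compound 4 (within the scatter), that is, no movement beyond the usual spread. Compound 4 is estimated at 9.3, with a range from 9 to 9.6.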

Compound 4, acid dissociation constant: 9.28
Compound 4: the middle estimate sits 0.02 log units above what was measured; the range from low to high includes it.
By their numbers in this assay, from the lowest: compounds 3, 4, 1 and 2 (each within the scatter of the next).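

In this assay, the change from 4-methoxyphenoxy to 2-methoxyphenoxy gives no change at the digits printed from compound 3 to compound 4 (within the scatter). Unlike the earlier steps, which exchanged one group for a different one, this step keeps the same atoms, joined differently, and so shows that relocating the methoxy group within this substituent, on the same oxygen on an aromatic ring, also leaves the reading within the scatter. Compound 4 also stands where compound 3 stood against the other two compounds, with a number 0.19 log units lower from compound 2 to compound 4 (within the scatter) and with a number 0.19 log units lower from compound 1 to compound 4 (within the scatter), so all six pairs among the four compounds now lie within the scatter, and none of the four substituents separates from the others, while no evidence is available to explain this flat result.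

The 4-methoxyphenyl and 2-methoxyphenyl groups carry no net charge, so the compounds shown leave open whether this reading would stay put with an amine or a carboxylic acid on that ring. For the compounds shown here, they also leave open how the reading would respond to a longer chain in place of the one that all four compounds share, since every change so far lies in a single place on the core.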